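Methoxy to hydroxy in the benzimidazole-free notation: compound 3

This account rests on a few compounds, and the source may have more. Where it says the series, first, only, none or still open, it means among the compounds named here.

PLACEHOLDER

Methoxy to hydroxy: the step to compound 3

- compound 1 `COc1ccc2c(c1)nc(/C=C/C(=O)/C=C/c1ccc(O)c(OC)c1)n2C`: 12700 nM
- compound 2 `COc1ccc2c(c1)nc(/C=C/C(=O)/C=C/c1ccc(OC)c(O)c1)n2C`: 11700 nM

Both values come from a functional assay on NCI-H460 cells (Homo sapiens) for cytotoxicity, read by MTT assay, with a stated time of 48 h; on this read-out lower numbers stand for stronger inhibition and higher numbers for weaker inhibition. Compound 2 stands level with compound 1 within the scatter, as a 1.1-fold lower number from compound 1 to compound 2 (0.04 log units; within the scatter) shows. Compound 3 `COc1ccc(/C=C/C(=O)/C=C/c2nc3cc(O)ccc3n2C)cc1O` is the next compound to be read in this assay. Its difference from compound 2 is hydrogen in place of methyl on an oxygen on an aromatic ring, which is hydrogen in place of methyl on an oxygen on an aromatic ring, or methoxy to hydroxy. For the measured compounds named here, the only measured step exchanged 4-hydroxy-3-methoxyphenyl for 3-hydroxy-4-methoxyphenyl, so it bears on this change only indirectly, and no measured step covers the change itself. With so little evidence, no shift beyond the scatter is expected in either direction. The expected move is a 1.0-fold higher number from compound 2 to compound 3 (0.01 log units; within the scatter). Compound 3 is estimated at 12000 nM, with an expected range of 5000 nM to 30000 nM.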

Compound 3, half-maximal inhibitory concentration: 7200 nM
Compound 3: the middle estimate sits 1.7-fold (0.22 log units) above what was measured; the range from low to high includes it.
By their numbers in this assay, from the lowest: compounds 3, 2 and 1 (each within the scatter of the next).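

For the compounds shown here, removing the methyl from the methoxy on the shared core gives a 1.6-fold lower number from compound 2 to compound 3 (0.21 log units; within the scatter) in this assay, so this is the first reading of a change at this oxygen, since the earlier step touched only the other aromatic ring. At this oxygen on an aromatic ring, methoxy and hydroxy therefore stand level in this read-out, and the free hydroxy neither costs nor gains anything that can be told from the scatter. No measurement on hand bears on the reason for the size of this step.

Going by these compounds, whether an amine or a longer chain such as ethoxy at this oxygen's place would move the number beyond the scatter stays open. Also open, on these data alone, is whether methoxy to hydroxy reads the same with 4-hydroxy-3-methoxyphenyl on the chain.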